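Ethylphenyl for chlorophenyl on the hydrazone nitrogen

The source may report more compounds than this note shows. Statements on the series, on what has been measured and on what is new or still open speak of the compounds shown alone.

compound 1 `CC1CC/C(=N\Nc2ccccc2Cl)c2ncc(C(=O)O)c(=O)n21`: > 1000 umol/kg
compound 2 `CC1CC/C(=N\Nc2ccccc2C(F)(F)F)c2ncc(C(=O)O)c(=O)n21`: > 1000 umol/kg
compound 3 `CC1CCC(=NNc2ccccc2C(=O)O)c2ncc(C(=O)O)c(=O)n21`: > 100 umol/kg; > 100 umol/kg; > 100 umol/kg (3 entries)

In a functional assay on the whole organism for inhibition, with Rattus norvegicus as the target (a higher number here means that more compound is needed for the effect, a lower number that less compound is needed), compound 1 gives > 1000 umol/kg, which is a limit of the assay and not a number. Compound 2 gives > 1000 umol/kg in this assay, also a limit. Compound 3 gives > 100 umol/kg; > 100 umol/kg; > 100 umol/kg (3 entries) in this assay, a limit reported in three entries. The single step that joins two of these compounds, a step that the two limits leave unreadable from compound 1 to compound 2, cannot be read because of the limit of > 1000 umol/kg in this assay, at which 2 of the 3 values shown sit. Compound 1 therefore stands only at a limit, with no number above or beside it.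

Compound 4 `CCc1ccc(N/N=C2\CCC(C)n3c2ncc(C(=O)O)c3=O)cc1` differs from compound 1 by 4-ethylphenyl in place of 2-chlorophenyl on an amine nitrogen. Going by the values given here, no measured step carries this change, and the one measured step gives no size to scale from. With nothing pointing either way, the expectation for compound 4 in this assay rests on the limit of compound 1 alone. Compound 4 is estimated at 1500 umol/kg, with a range from 400 umol/kg to 5000 umol/kg. For compound 4 this estimate amounts to a step that the limit leaves unreadable from compound 1 to compound 4, a step expected to stay within the scatter, and most likely the assay again reports only a limit.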

Compound 4, dose for 50% inhibition: > 1000 umol/kg
Compound 4: no number, only a limit; the forecaster's own chance of this, stated with the estimate: 80%; the middle value does not contradict the limit.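

In this assay compound 4 gives > 1000 umol/kg, a limit of the assay and not a number. No step can be read from compound 1 to compound 4, because both stop at one limit: the limit of > 1000 umol/kg in this assay, at which 3 of the 4 values shown sit. The compounds shown leave open whether 4-ethylphenyl and 2-chlorophenyl differ at all in this assay.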